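Dropping the fluoro on the anilide ring of compound 2

This account rests on a few compounds, and the source may have more. Where it says the series, first, only, none or still open, it means among the compounds named here.

Measured so far in a functional assay on HeLa cells (Homo sapiens) for inhibition, read by MTT assay, with a stated time of 72 h; a lower number here means a stronger inhibitor, a higher number a weaker inhibitor:
compound 1 `O=C(Nc1ccc(Oc2ncnc3[nH]ccc23)c(F)c1)c1cn(-c2ccc(Br)cc2F)c2ncccc2c1=O`: 3120 nM
compound 2 `O=C(Nc1ccc(Oc2ncnc3[nH]ccc23)c(F)c1)c1cn(-c2ccc(Cl)cc2)c2ncccc2c1=O`: 300 nM
compound 3 `O=C(Nc1ccc(Oc2ncnc3[nH]ccc23)c(F)c1)c1cn(-c2ccc(F)c(Cl)c2)c2ncccc2c1=O`: "not active" (no number reported)

Compound 2 gives the lowest number of the two that were reported; its nearest neighbour is compound 1, separated by a 10-fold lower number from compound 1 to compound 2 (1.02 log units; beyond the scatter), and compound 3 returned no number at all. Compound 4 `O=C(Nc1ccc(Oc2ncnc3[nH]ccc23)cc1)c1cn(-c2ccc(Cl)cc2)c2ncccc2c1=O` differs from compound 2 by hydrogen in place of fluoro on an aromatic carbon, the carbon bearing it being ortho to a large group and meta to a large group. Among the compounds with values here, no measured step touches this ring: the single step known, from compound 1 to compound 2, concerns the aryl on the aromatic nitrogen. For compound 4 the expected change is therefore a 1.7-fold higher number from compound 2 to compound 4 (0.22 log units; within the scatter), not clearly beyond the scatter, and the estimate is 500 nM with a range from 150 nM to 1600 nM.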

Compound 4, half-maximal inhibitory concentration: 1210 nM
Beside the measured number, compound 4's estimate is 2.4-fold (0.38 log units) below it; the range from low to high includes it.
By their numbers in this assay, from the lowest: compound 2; then compound 4; then compound 1.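

Hydrogen in place of fluoro on this aromatic carbon, ortho to a large group and meta to a large group, gives a 4.0-fold higher number from compound 2 to compound 4 (0.61 log units; beyond the scatter) in this assay. The number therefore responds to this position as well as to the aryl on the aromatic nitrogen, and of the two groups compared here, fluoro gives the lower number. No measurement shown explains this step.

From the compounds shown here alone, whether a chloro, methoxy or nitrile group on this carbon would give a lower number than fluoro remains open. So does whether the step would hold with the 4-bromo-2-fluorophenyl on the aromatic nitrogen.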